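Chloro in place of hydrogen: the step to compound 4

The source may hold more compounds than are shown below. What is called first, only, known or untested is meant among the compounds shown, and "the series" means these compounds.

In a physicochemical assay for lipophilicity, at pH 7.4 (on this read-out higher numbers stand for higher lipophilicity and lower numbers for lower lipophilicity), compound 2 `c1ccc(C2CCc3nc[nH]c3C2)cc1` gives 2.6. Compound 1 `COc1cccc(C2CCc3nc[nH]c3C2)c1` gives 2.6, and compound 3 `Clc1ccccc1C1CCc2nc[nH]c2C1` gives 3.1. Compound 2 therefore stands level with compound 1 and lower than compound 3.

Compound 4 `Clc1cccc(C2CCc3nc[nH]c3C2)c1` has not yet been measured. Its structure departs from that of compound 2 as follows: chloro in place of hydrogen on an aromatic carbon.

Within the data shown here, the closest precedent is the same exchange of hydrogen for chloro, which gave a number 0.50 log units higher from compound 2 to compound 3 (beyond the scatter). That single step is modest, and compound 3 and compound 4 carry the chloro at different places on the ring, so the transfer is uncertain. The other measured step, no change at the digits printed from compound 1 to compound 2 (within the scatter), involves methoxy rather than chloro and bears on the question only weakly.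

A rise of similar size is therefore expected, and the estimated step is a number 0.50 log units higher from compound 2 to compound 4 (beyond the scatter). For compound 4 the estimated value is 3.1, with an expected range from 2.8 to 3.4.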

Compound 4, distribution coefficient: 3.3
Compound 4: the middle estimate sits 0.20 log units below what was measured, and the stated range covers the measured number.
By their numbers in this assay, from the lowest: compounds 1 and 2 (each within the scatter of the next); then compounds 3 and 4 (each within the scatter of the next).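

In this assay, chloro in place of hydrogen on this aromatic carbon, meta to the group of 9 heavy atoms, gives a number 0.70 log units higher from compound 2 to compound 4 (beyond the scatter), so a rise with chloro is no longer confined to the place it occupies in compound 3. The same position had shown no difference between methoxy and hydrogen, yet chloro in place of methoxy gives a number 0.70 log units higher from compound 1 to compound 4 (beyond the scatter), so the read-out at this position does respond to the group placed there. Compound 3 and compound 4 lie within the scatter of each other, so the two chloro places cannot be told apart on these numbers.

Nothing available gives a reason for these steps. Going by these compounds, whether an amine or a carboxylic acid on this aromatic carbon would bring the number below that of compound 2 remains open.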